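Sulfur in place of selenium, repeated on a second core

The source may hold more compounds than are shown below. What is called first, only, known or untested is meant among the compounds shown, and "the series" means these compounds.

Compound 1 `C[Se]/C(=N\C(=O)c1ccco1)NC(=O)c1ccco1` is the reference of the series. In a functional assay on HepG2 cells (Homo sapiens) for cytotoxicity, read by MTT assay, with a stated time of 72 h (a higher number here means a weaker inhibitor of growth, a lower number a stronger inhibitor of growth), compound 1 gives 760 nM. Compound 2 `CS/C(=N\C(=O)c1ccco1)NC(=O)c1ccco1` carries a group of 2 heavy atoms (1 carbon, 1 sulfur; no ring) in place of a group of 2 heavy atoms (1 carbon, 1 selenium; no ring), on a carbon with a double bond to nitrogen. For compound 2 in this assay only a limit is reported, > 100000 nM. The step of an at least 130-fold higher number from compound 1 to compound 2 (2.11 log units; beyond the scatter) is thus a large loss, as far as the assay can show it; the evidence on this step is the limit of > 100000 nM in this assay, at which 1 of the 3 values shown sits.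

Compound 3 `C[Se]/C(=N\C(=O)c1cnc2ccccc2c1)NC(=O)c1cnc2ccccc2c1` is built on a different core; the difference between the core of compound 1 and the core of compound 3 is not broken down here. In this assay compound 3 gives 4160 nM, the highest of the two measured numbers, with compound 1 the nearest at a lower number.

Compound 4 `CS/C(=N\C(=O)c1cnc2ccccc2c1)NC(=O)c1cnc2ccccc2c1` is not yet measured. It relates to compound 3 as compound 2 relates to compound 1: a group of 2 heavy atoms (1 carbon, 1 sulfur; no ring) in place of a group of 2 heavy atoms (1 carbon, 1 selenium; no ring), on a carbon with a double bond to nitrogen. The surroundings of the exchanged group read the same in both pairs, so this is the same change, made a second time on a second core. Among the compounds shown it occurs twice in all, and only one instance is measured. The step of a 36-fold higher number from compound 3 to compound 4 (1.56 log units; beyond the scatter) is expected to be of the same kind, a large loss, because the measured instance is an at least 130-fold higher number from compound 1 to compound 2 (2.11 log units; beyond the scatter). Compound 3 already starts from a higher number than compound 1, so the result is expected to reach the limit of the assay. For compound 4 in this assay the estimate is 150000 nM, most probably reported as a limit rather than a number, with an expected range from 40000 nM to 600000 nM.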

Compound 4, concentration for 50% growth inhibition: 57600 nM
For compound 4 the middle estimate is 2.6-fold (0.42 log units) above the measured one; the range from low to high includes it.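

On the second core, the exchange of the selenium group for methylsulfanyl gives a 14-fold higher number from compound 3 to compound 4 (1.14 log units; beyond the scatter) in this assay, so the direction of the step carries over and it is a large loss on both cores. The size does not carry over as a fixed amount, and two pairs give no rule for a further core: the same change on two cores in this assay, an at least 130-fold higher number (2.11 log units; beyond the scatter) from compound 1 to compound 2 and a 14-fold higher number (1.14 log units; beyond the scatter) from compound 3 to compound 4, at least 9.5-fold (0.97 log units) apart, beyond the scatter of two such steps

Compound 2 is known only as a limit, so the full size of its step, and with it the full gap between the two steps, stays open: the limit of > 100000 nM in this assay, at which 1 of the 4 values shown sits.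

The compounds shown leave open how the series responds to other groups on the carbon with a double bond to nitrogen, such as a longer chain on the selenium or an amine in place of the methylsulfanyl. They also leave open whether the loss holds on a third core, and whether the same direction appears in any read-out other than this assay.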